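Replacing a pyrazole amide with a methylazetidine: solubility outlook

The compounds below may be only part of what the source reports. "The series", "measured", "known", "first", "only" and "open" are said of these compounds alone.

Compound 3 `Cn1cc(NC(=O)c2ccncc2Nc2cc(-c3ccc4ccn(C)c4c3)c3nccnc3c2)cn1` gives 2 ug/mL in a physicochemical assay for solubility, read by spectrophotometry, measured as kinetic solubility, at pH 8, tested at 500 uM; a lower number here means a less soluble compound, a higher number a more soluble compound; it stands level with compound 2 `Cn1ccc2ccc(-c3cc(Nc4ccccc4S(=O)(=O)NCC4CCOCC4)cc4nccnc34)cc21`, which gives 2 ug/mL, and these two are together the lowest of the three numbers, while compound 1 `Cn1ccc2ccc(-c3cc(Nc4ccccc4S(=O)(=O)N4CCOCC4)cc4nccnc34)cc21` gives 5 ug/mL. Within the data shown here, the only measured step, a 2.5-fold lower number from compound 1 to compound 2 (0.40 log units; beyond the scatter), concerns a sulfonyl substituent and does not bear on the change now considered. Compound 4 `CN1CC(NC(=O)c2ccncc2Nc2cc(-c3ccc4ccn(C)c4c3)c3nccnc3c2)C1` differs from compound 3 by 1-methylazetidin-3-yl in place of 1-methyl-1H-pyrazol-4-yl on an amide-type nitrogen. Among the measured compounds shown here, with no measured step covering this change, the expectation for compound 4 in this assay rests on compound 3 alone, and a step of a 2.0-fold higher number from compound 3 to compound 4 (0.30 log units; within the scatter) is estimated, about level or slightly higher. Compound 4 is therefore expected to give 4 ug/mL, within a range from 1 ug/mL to 15 ug/mL.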

Compound 4, solubility: 170 ug/mL
Compound 4: middle estimate off by 43-fold (1.63 log units), on the low side; the whole stated range lies below it.
By their numbers in this assay, from the lowest: compounds 2 and 3 (each within the scatter of the next); then compound 1; then compound 4.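

At this amide-type nitrogen, one change of group produces an 85-fold higher number from compound 3 to compound 4 (1.93 log units; beyond the scatter) in this assay, so this position can move the number far more than the sulfonyl substituent change did in a 2.5-fold lower number from compound 1 to compound 2 (0.40 log units; beyond the scatter). The pair also shows that a non-aromatic ring here is compatible with a much higher number than the aromatic pyrazole gives. Nothing shown accounts for the size of this step.

As far as these compounds go, whether the step depends on the four-membered ring or would also appear with a 1-methylpiperidin-4-yl ring or an open-chain dimethylaminoethyl group at this place remains open. From the compounds shown here alone, it also remains open whether the step holds on other cores, as it rests on one pair.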